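The source may report more compounds than this note shows. Statements on the series, on what has been measured and on what is new or still open speak of the compounds shown alone.

Compounds measured in a functional assay on HA22T cells for cytotoxicity against HA22T cell line (Homo sapiens); on this read-out higher numbers stand for weaker inhibition and lower numbers for stronger inhibition:
- compound 1 `N#C/N=C1\N(CCCCCOc2ccc(Cl)cc2)C(=O)CN1c1ccncc1`: 8970 nM
- compound 2 `CCC1C(=O)N(CCCCCCOc2ccc(Cl)cc2)/C(=N\C#N)N1c1ccncc1`: 5130 nM
- compound 3 `CCC1C(=O)N(CCCCCCCOc2ccc(Cl)cc2)/C(=N\C#N)N1c1ccncc1`: 6050 nM

In this assay compound 3 gives 6050 nM, and this number lies within the scatter of both other compounds: the step of a 1.2-fold higher number from compound 2 to compound 3 (0.07 log units; within the scatter) is within the scatter, and compound 1 with 8970 nM is within the scatter of compound 3 as well. The three numbers therefore show no difference that can be read as real.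

Compound 4 `N#C/N=C1\N(CCCCCCCOc2ccc(Cl)cc2)C(=O)C(c2ccccc2)N1c1ccncc1` differs from compound 3 by phenyl in place of ethyl on a saturated ring carbon. For the measured compounds named here, no measured step bears on this change: the only step, a 1.2-fold higher number from compound 2 to compound 3 (0.07 log units; within the scatter), concerns the chain and not the substituent on the saturated ring carbon. Compound 1 carries no group on that carbon and compound 2 carries ethyl, but these two also differ in the chain, and their values lie within the scatter of each other. On this basis the expected step of a 1.0-fold lower number from compound 3 to compound 4 (0.00 log units; within the scatter) is none beyond the scatter, with the range kept wide for the untested change. Compound 4 is estimated at 6000 nM, between 2500 nM and 15000 nM.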

Compound 4, half-maximal inhibitory concentration: 831 nM
Beside the measured number, compound 4's estimate is 7.2-fold (0.86 log units) above it; the measured number lies below the stated range.
By their numbers in this assay, from the lowest: compound 4; then compounds 2, 3 and 1 (each within the scatter of the next).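

The saturated ring carbon next to the ring nitrogen proves to be a place where the number can move in this assay: phenyl in place of ethyl gives a 7.3-fold lower number from compound 3 to compound 4 (0.86 log units; beyond the scatter). The values of compounds 1, 2 and 3 all lay within the scatter of one another, so none of them had shown a real difference, and this is the first change here that goes beyond it. The result rests on a single pair, and nothing available accounts for this step.

The compounds shown leave open whether the lower number belongs to phenyl itself or would also follow from another group on this carbon, such as cyclohexyl, benzyl or pyridin-3-yl. They also leave open whether phenyl would give a similar step on the chain of compound 2.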